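The compounds below may be only part of what the source reports. "The series", "measured", "known", "first", "only" and "open" are said of these compounds alone.

Cytotoxicity in a functional assay on Col2 cells (Homo sapiens) for cytotoxicity, read by sulforhodamine B assay (a lower number here means that less compound is needed, a higher number that more compound is needed for the effect), for the measured compounds:
compound 1 `C=C1CC[C@@H]2[C@](C)(COC(C)=O)[C@H](OC(C)=O)CC[C@@]2(C)[C@@H]1C/C=C1/C(=O)OC[C@H]1OC(C)=O`: 10.8 uM
compound 2 `C=C1CC[C@@H]2[C@](C)(CO[Si](c3ccccc3)(c3ccccc3)C(C)(C)C)[C@H](OC(C)=O)CC[C@@]2(C)[C@@H]1C/C=C1/C(=O)OC[C@H]1OC(C)=O`: 12.3 uM
compound 3 `C=C1CC[C@@H]2[C@](C)(COC(C)=O)[C@H](O)CC[C@@]2(C)[C@@H]1C/C=C1/C(=O)OC[C@H]1OC(C)=O`: 15.2 uM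

All three numbers lie within the scatter of one another. Within the data shown here, the single one-point change that has been measured is hydrogen in place of acetyl on an oxygen on a saturated carbon. It gave a 1.4-fold higher number from compound 1 to compound 3 (0.15 log units; within the scatter). Compound 2 carries a different core from compound 1; the difference between the two cores is not broken down here. Compound 4 `C=C1CC[C@@H]2[C@](C)(CO[Si](c3ccccc3)(c3ccccc3)C(C)(C)C)[C@H](O)CC[C@@]2(C)[C@@H]1C/C=C1/C(=O)OC[C@H]1OC(C)=O` is compound 2 with the same change applied: hydrogen in place of acetyl on an oxygen on a saturated carbon. The place of the change reads the same in both pairs, so this is the same change made on the other core. Among the measured compounds shown here, only that one earlier instance exists, and the expectation for compound 4 rests on a 1.4-fold higher number from compound 1 to compound 3 (0.15 log units; within the scatter) together with compound 2 giving 12.3 uM in this assay, a number within the scatter of compound 1. For compound 4 the expected step is a 1.4-fold higher number from compound 2 to compound 4 (0.14 log units; within the scatter), set beside the earlier 1.4-fold higher number from compound 1 to compound 3 (0.15 log units; within the scatter). Compound 4 is accordingly estimated at 17 uM in this assay, with a range from 8 uM to 35 uM.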

Compound 4, concentration for half-maximal effect: 10.7 uM
Compound 4: the middle estimate sits 1.6-fold (0.20 log units) above what was measured; low and high end bracket the measured number.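

Acetoxy to hydroxy, on an oxygen on a saturated carbon, gives a 1.1-fold lower number from compound 2 to compound 4 (0.06 log units; within the scatter) in this assay, and this step sits with the earlier one as follows: the same change on two cores in this assay, a 1.4-fold higher number (0.15 log units; within the scatter) from compound 1 to compound 3 and a 1.1-fold lower number (0.06 log units; within the scatter) from compound 2 to compound 4, 1.6-fold (0.21 log units) apart, within the scatter of two such steps

On the two cores shown, the change therefore behaves alike, with no step that stands out from the scatter. This does not give the change a direction or a size in this assay, and two pairs say nothing about how it would behave on any other core.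

At this oxygen the compounds shown carry only hydrogen or acetyl, so it remains open whether a longer acyl chain such as hexanoyl, a methyl ether or a carbamate would give a number beyond the scatter. On these data alone, the acetoxy group on the lactone ring is the same in all four compounds, so the effect of hydroxy or an amine in its place also remains open.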